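Bromo for fluoro in a dipeptidyl peptidase 9 series

The source may report more compounds than this note shows. Statements on the series, on what has been measured and on what is new or still open speak of the compounds shown alone.

Compound 1 `CC#CCn1c(N2CCC[C@@H](N)C2)cc(=O)n(Cc2ccc(F)c(C(=O)O)c2)c1=O` is known in an assay on isolated protein for inhibition of Dipeptidyl peptidase 9 (Homo sapiens), read by fluorescence, with stated times of 15 min and 20 min (on this read-out lower numbers stand for stronger inhibition and higher numbers for weaker inhibition), only by a limit of the assay: in this assay compound 1 gives > 100 nM, which is not a number. Compound 2 `CC#CCn1c(N2CCC[C@@H](N)C2)cc(=O)n(Cc2cc(Br)cc(C(=O)OC)c2)c1=O` is likewise known only by a limit, giving > 100 nM in this assay. For the measured compounds named here, compound 1 thus stands with the whole set so far, at the limit of > 100 nM in this assay, at which 2 of the 2 values shown sit, and no step between measured compounds can be drawn from it.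

Compound 3 `CC#CCn1c(N2CCC[C@@H](N)C2)cc(=O)n(Cc2ccc(Br)c(C(=O)O)c2)c1=O` differs from compound 1 by bromo in place of fluoro on an aromatic carbon. Going by the values given here, because both values so far sit at the limit of > 100 nM in this assay, at which 2 of the 2 values shown sit, the change is expected to bring no step beyond the scatter, and another limit is the most likely outcome. Compound 3 is therefore expected to give 300 nM in this assay, between 100 nM and 1000 nM. The expected step is a step that the limit leaves unreadable from compound 1 to compound 3.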

Compound 3, half-maximal inhibitory concentration: > 100 nM
Compound 3: no number, only a limit (the forecaster's own chance of this, stated with the estimate: 75%); the middle value is on the limit's open side.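

In this assay compound 3 gives > 100 nM as a limit of the assay and not a number. For the compounds shown here, compound 1 is also known only by a limit, and no step from compound 1 to compound 3 can be read. The compounds shown leave open how strongly any of them inhibits the enzyme, and whether bromo in place of fluoro changes that at all.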